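The source may report more compounds than this note shows. Statements on the series, on what has been measured and on what is new or still open speak of the compounds shown alone.

Compound 2 `COc1cc(N(C)CCN(C)C)c(NC(=O)c2ccncn2)cc1Nc1nc(-c2cn(C)c3ccccc23)c2cccnc2n1` was tested in a functional assay on NCI-H1975 cells (Homo sapiens) for antiproliferative activity, read by MTT assay, with a stated time of 72 h (a higher number here means a weaker inhibitor, a lower number a stronger inhibitor), where compound 2 gives 1090 nM. For the measured compounds named here, only one other compound has been measured in this assay: compound 1 `COc1ccc(C(=O)Nc2cc(Nc3nc(-c4cn(C)c5ccccc45)c4cccnc4n3)c(OC)cc2N(C)CCN(C)C)nc1`, which gives 1160 nM; the two numbers cannot be told apart, since a 1.1-fold lower number from compound 1 to compound 2 (0.03 log units; within the scatter) lies within the scatter. Compound 3 `COc1cc(N(C)CCN(C)C)c(NC(=O)c2nccn2C)cc1Nc1nc(-c2cn(C)c3ccccc23)c2cccnc2n1` carries 1-methyl-1H-imidazol-2-yl in place of pyrimidin-4-yl on a carbonyl carbon. Going by the values given here, the one step that bears on this change, a 1.1-fold lower number from compound 1 to compound 2 (0.03 log units; within the scatter), also swapped one aromatic ring for another on that carbonyl carbon and moved nothing beyond the scatter, so no step beyond the scatter is expected here, a 1.0-fold higher number from compound 2 to compound 3 (0.00 log units; within the scatter). Compound 3 is therefore estimated at 1100 nM, with a range from 500 nM to 2500 nM.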

Compound 3, half-maximal inhibitory concentration: 4200 nM
Compound 3: the middle estimate sits 3.8-fold (0.58 log units) below what was measured, outside the stated range (above it).
By their numbers in this assay, from the lowest: compounds 2 and 1 (each within the scatter of the next); then compound 3.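

Putting 1-methyl-1H-imidazol-2-yl on this carbonyl carbon gives a 3.9-fold higher number from compound 2 to compound 3 (0.59 log units; beyond the scatter) and a 3.6-fold higher number from compound 1 to compound 3 (0.56 log units; beyond the scatter), so exchanging one aromatic ring for another at this position does not always leave the number unchanged. The five-membered ring that enters has the same heavy-atom and hetero-atom counts as the six-membered pyrimidin-4-yl that leaves, so matching counts do not ensure matching activity. Nothing available explains this shift.

The compounds shown do not separate the effect of ring size from that of the methyl group, which a 1H-imidazol-2-yl group could help to do. On these data alone, how a non-aromatic group, such as an amine or a longer alkyl chain, behaves here also stays open.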